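A few compounds are considered here, and "the series" means these few. Any claim that something is new, unique, unknown or untested is made for them only; others in the source may bear on it.

Measured compounds:
Compound 1, `Cc1oc(-c2ccc(F)cc2)nc1CN1CCC(C(=O)NCCCN2C[C@H](C)C[C@H](C)C2)CC1`, gives 12800 nM in an ADME assay on Huh7.5.1 cells (Homo sapiens) for cytotoxicity, read by ATP content, with a stated time of 48 h; a lower number here means that less compound is tolerated, a higher number that more compound is tolerated.
Compound 2, `Cc1ccccc1-c1nc(CN2CCC(C(=O)NCCCN3CC4CCCC(C4)C3)CC2)c(C)o1`, gives 10900 nM in this assay.

These two numbers tell how much of each compound the liver-derived cells tolerate before their energy content falls by half. Compound 1 and compound 2 lie within the usual scatter of each other, so on the numbers shown they cannot be told apart, and neither can be called the better tolerated of the two.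

The next compound, compound 3, `Cc1cc(C)cc(-c2nc(CN3CCC(C(=O)NCCCN4C[C@H](C)C[C@H](C)C4)CC3)c(C)o2)c1`, shares the core of compound 1 and differs from it in one place: 3,5-dimethylphenyl in place of 4-fluorophenyl on an aromatic carbon. Going by the values given here, no measured pair in this set shows a change of just this kind, so nothing here tells how large a step it brings.

Among the compounds with values here, with no comparable step to draw on, the expectation for compound 3 rests on compound 1 and its value of 12800 nM alone. The step of a 1.3-fold lower number from compound 1 to compound 3 (0.11 log units; within the scatter) is expected to stay within the scatter, with no clear direction. Compound 3 is therefore estimated at 10000 nM, in a range from 4000 nM to 25000 nM.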

Compound 3, half-maximal cytotoxic concentration: 4050 nM
The estimate for compound 3 lay 2.5-fold (0.39 log units) above the measured number, and the stated range covers the measured number.
By their numbers in this assay, from the lowest: compound 3; then compounds 2 and 1 (each within the scatter of the next).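

Placing 3,5-dimethylphenyl in place of 4-fluorophenyl on this aromatic carbon, next to the ring nitrogen and next to the ring oxygen, gives a 3.2-fold lower number from compound 1 to compound 3 (0.50 log units; beyond the scatter) in this assay, so the cells tolerate less of the compound after the change. This is the only step shown between compounds that differ in one place, and it shows that the group on this carbon can move the number beyond the scatter, even though the two groups each hold one six-membered aromatic ring of carbon only and neither has a hydrogen-bond donor or acceptor. No measurement at hand explains why the number falls with this change.

Going by these compounds alone, the single step removes the fluorine and adds two methyl groups at once, so it leaves open whether the loss of the one, the arrival of the other or both together lie behind the lower number. On these data alone, how an unsubstituted phenyl ring, a chlorophenyl group or a methoxyphenyl group on this carbon would compare also remains open.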